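A Second Chloro Group and Expected Cytotoxicity

The compounds below may be only part of what the source reports. "The series", "measured", "known", "first", "only" and "open" are said of these compounds alone.

Compound 1, `COc1ccc(S(=O)(=O)/C=C/c2ccccn2)cc1`, is the starting point. In an ADME assay on BV-2 cells (Mus musculus) for cytotoxicity, with a stated time of 24 h, tested at 50 uM (on this read-out higher numbers stand for a weaker effect at the one concentration tested and lower numbers for a stronger effect), compound 1 gives 100%. Compound 2, `COc1ccc(S(=O)(=O)/C=C/c2ncccc2Cl)cc1`, differs from compound 1 by chloro in place of hydrogen on an aromatic carbon, and in this assay compound 2 gives 89.8%. Going by the values given here, the resulting step, a number 10.2 percentage points lower from compound 1 to compound 2 (beyond the scatter), is the only measured example of this kind of change.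

Compound 3, `COc1ccccc1S(=O)(=O)/C=C/c1cccnc1Cl`, rests on another core; the difference between the two cores is not broken down here. In this assay compound 3 gives 87.5%, which sits within the scatter of the value of compound 2, while the values of compound 3 and compound 1 show a gap beyond the scatter.

Compound 4, `COc1ccccc1S(=O)(=O)/C=C/c1ccc(Cl)nc1Cl`, has not yet been measured. It is made from compound 3 by chloro in place of hydrogen on an aromatic carbon. This is the same kind of change as from compound 1 to compound 2, but not the same change: there the chloro entered ortho to a large group, two atoms from the ring nitrogen; here it enters next to the ring nitrogen, meta to a chloro group and para to a large group.

The expected step is a number 9.5 percentage points lower from compound 3 to compound 4 (within the scatter), and it rests on the measured step of a number 10.2 percentage points lower from compound 1 to compound 2 (beyond the scatter) being of similar size. Compound 4 is therefore expected to give about 78% in this assay, with an estimated range from 64% to 92%.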

Compound 4, a percentage reported as activity, at one concentration (the size of the read-out at that concentration, not a potency): 99.8%
For compound 4 the middle estimate is 21.8 percentage points below the measured one; the measured number lies above the stated range.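

In this assay, putting chloro in place of hydrogen on an aromatic carbon gave a number 12.3 percentage points higher from compound 3 to compound 4 (beyond the scatter), so here the number moved towards a weaker effect at the one concentration tested. Set beside the earlier example, this shows that the size and direction of the step did not carry over from one core to the other: the same change on two cores in this assay, a number 10.2 percentage points lower (beyond the scatter) from compound 1 to compound 2 and a number 12.3 percentage points higher (beyond the scatter) from compound 3 to compound 4, 22.5 percentage points apart, beyond the scatter of two such steps. Going by these compounds alone, it does not show what lies behind the gap, since the two chloro groups differ both in their core and in their place on the ring, with the one in compound 4 next to the ring nitrogen and para to a large group, and two steps are too few to support a rule for the series.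

Still open, from the compounds shown here alone, is whether chloro at this same place on the core of compound 1 would give a step like the one seen on the core of compound 3, which would help to separate the effect of place from that of core. The compounds shown also leave open how a different group at this place, such as an amine or a carboxylic acid, would change the read-out.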